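This account rests on a few compounds, and the source may have more. Where it says the series, first, only, none or still open, it means among the compounds named here.

Of the compounds shown here, two built on a shared core have been measured in an ADME assay on LLC-MK2 cells (Macaca mulatta) for cytotoxicity, read by spectrophotometry and crystal violet staining, with a stated time of 4 days; on this read-out lower numbers stand for higher toxicity in this test and higher numbers for lower toxicity in this test. Compound 1 `CC(C)n1ncc2c(C(=O)Nc3ccccn3)cc(-c3ccsc3)nc21` gives 25000 nM in this assay, while compound 2 `CC(C)n1ncc2c(C(=O)Nc3ccncc3)cc(-c3cccs3)nc21` gives 6300 nM. Among the measured compounds shown here, compound 2 therefore stands at the lowest of the two numbers so far; its nearest neighbour, compound 1, lies at a higher number, and that gap is beyond the usual scatter. Compound 3 `CC(C)n1ncc2c(C(=O)Nc3ccc(F)cc3F)cc(-c3cccs3)nc21` has not yet been measured in this assay. It differs from compound 2 in one place: 2,4-difluorophenyl in place of pyridin-4-yl on an amide-type nitrogen. No pair of measured compounds differing in a single place is available, so the size of such a step in this assay has no precedent among these numbers. The expected step, a 1.3-fold lower number from compound 2 to compound 3 (0.10 log units; within the scatter), is small and points toward a somewhat lower number, though it may well not exceed the scatter. Compound 3 is accordingly estimated at 5000 nM, within a range from 1500 nM to 16000 nM.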

Compound 3, half-maximal cytotoxic concentration: > 200000 nM
Compound 3: a limit, no number (the forecaster's own chance of this, stated with the estimate: 20%); middle value at least 40-fold (1.60 log units) away from the limit.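

In this assay compound 3 gives > 200000 nM, which is a limit of the assay and not a number. Setting 2,4-difluorophenyl in place of pyridin-4-yl on the amide-type nitrogen gives an at least 31-fold higher number from compound 2 to compound 3 (1.50 log units; beyond the scatter), the first step in these data that changes one place only, and it shows that this position alone can shift the read-out strongly toward lower toxicity in this test. The full size of the step stays unknown, as its upper end is set by the limit: the limit of > 200000 nM in this assay, at which 1 of the 3 values shown sits.

The compounds shown do not separate the loss of the pyridine nitrogen from the gain of the two fluorines, and plain phenyl or a monofluorophenyl at this position would be needed to tell these apart. As far as these compounds go, whether the same change would have a similar effect with another group on the shared core also remains open.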